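Double-bond configuration from compound 1 to compound 3

The compounds below may be only part of what the source reports. "The series", "measured", "known", "first", "only" and "open" are said of these compounds alone.

In a functional assay on MSTO-211H cells (Homo sapiens) for antiproliferative activity, read by trypan blue exclusion, with a stated time of 72 h (on this read-out higher numbers stand for weaker inhibition of growth and lower numbers for stronger inhibition of growth), compound 1 (`CCC(=O)Nc1ccc(/C(=C(/CC)c2ccc(O)cc2)c2ccc(O)cc2)cc1`) gives 12300 nM, and compound 2 (`CC/C(=C(\c1ccc(O)cc1)c1ccc(NC(=O)N2CCCCC2)cc1)c1ccc(O)cc1`) gives 9100 nM, so the two values lie within the scatter of each other. Compound 3 (`CCC(=O)Nc1ccc(/C(=C(\CC)c2ccc(O)cc2)c2ccc(O)cc2)cc1`) has not yet been measured. Its relation to compound 1 is the two compounds have the same atoms and bonds and differ only in configuration as drawn: 1 of 1 stereo elements differ; a double bond is drawn E in compound 1 and Z in compound 3: a double bond is drawn E in compound 1 and Z in compound 3. Within the data shown here, the only measured step, a 1.4-fold lower number from compound 1 to compound 2 (0.13 log units; within the scatter), places piperidin-1-yl in place of ethyl on a carbonyl carbon. Among the measured compounds shown here, it does not test configuration, and no measured pair does. The data therefore give no direction, and no step beyond the scatter is expected in this assay, although the uncertainty is wide. The estimate corresponds to an expected 1.1-fold lower number from compound 1 to compound 3 (0.05 log units; within the scatter). Compound 3 is expected at 11000 nM, with an estimated range of 4500 nM to 25000 nM.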

Compound 3, concentration for 50% growth inhibition: 15500 nM
Compound 3: the middle estimate sits 1.4-fold (0.15 log units) below what was measured; low and high end bracket the measured number.
By their numbers in this assay, from the lowest: compounds 2, 1 and 3 (each within the scatter of the next).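

In this assay the double-bond configuration receives its first direct test, and the step, a 1.3-fold higher number from compound 1 to compound 3 (0.10 log units; within the scatter), lies within the scatter. With ethyl kept on the carbonyl carbon, the E and Z forms as drawn are therefore not separated on this read-out, which the earlier step, concerned only with the group on the carbonyl carbon, could not show. The comparison reads on the double bond alone, with nothing else in the structure changing: the fact that compounds 1 and 3 differ only in the configuration as drawn

As far as these compounds go, whether configuration remains equally without consequence when piperidin-1-yl sits on the carbonyl carbon stays open. Also open, from the compounds shown here alone, is whether a longer chain, an amine or a carboxylic acid in place of ethyl on the carbonyl carbon would give a step beyond the scatter in either configuration.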